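The source may hold more compounds than are shown below. What is called first, only, known or untested is meant among the compounds shown, and "the series" means these compounds.

The measured compounds:
Compound 1 `Cc1ccc(-c2c3ccc4ccccc4c3nc3c2c(C)nc2c4ccccc4ccc32)cc1` gives 72200 nM in a functional assay on HeLa cells (Homo sapiens) for cytotoxicity, read by MTT assay, with a stated time of 48 h; on this read-out higher numbers stand for weaker inhibition and lower numbers for stronger inhibition.
Compound 2 `Cc1nc2c3ccccc3ccc2c2nc3c(ccc4ccccc43)c(C)c12` reaches only the limit > 80000 nM in this assay.
Compound 3 `Cc1nc2c3ccccc3ccc2c2nc3c(ccc4ccccc43)c(-c3ccccc3)c12` reaches only the limit > 80000 nM in this assay.

Compound 2 stands at the assay limit, where two of the three values sit (the limit of > 80000 nM in this assay, at which 2 of the 3 values shown sit). Compound 4 `Cc1nc2c3ccccc3ccc2c2nc3c(ccc4ccccc43)c(-c3ccccc3N)c12` differs from compound 2 by 2-aminophenyl in place of methyl on an aromatic carbon. The step most closely related to this change runs from compound 2 to compound 3, but that step is a step that the two limits leave unreadable from compound 2 to compound 3. The remaining steps, an at least 1.1-fold higher number from compound 1 to compound 2 (0.04 log units; that floor lies within the scatter) and an at least 1.1-fold higher number from compound 1 to compound 3 (0.04 log units; that floor lies within the scatter), are floors only. No readable size therefore supports a change beyond the scatter in this assay. Compound 4 is expected to remain near the limit, with a step of a number no higher from compound 2 to compound 4 (the limit leaves the size open). Compound 4 is estimated at 80000 nM, with a range from 30000 nM to 200000 nM.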

Compound 4, half-maximal inhibitory concentration: 16200 nM
For compound 4 the middle estimate is 4.9-fold (0.69 log units) above the measured one, outside the stated range (below it).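

Within the data shown here, on this aromatic carbon, opposite the ring nitrogen, 2-aminophenyl in place of methyl gives an at least 4.9-fold lower number from compound 2 to compound 4 (0.69 log units; beyond the scatter) in this assay, the first step that reads beyond the scatter. Amino in place of hydrogen gives an at least 4.9-fold lower number from compound 3 to compound 4 (0.69 log units; beyond the scatter), and 2-aminophenyl in place of 4-methylphenyl gives a 4.5-fold lower number from compound 1 to compound 4 (0.65 log units; beyond the scatter), the only one of these steps with a full size. The other two are floors, their true sizes open: the limit of > 80000 nM in this assay, at which 2 of the 4 values shown sit.

Going by these compounds, whether a hydroxyl, an aminomethyl group or a carboxylic acid in place of the amino would give a similar step stays open.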